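The source may hold more compounds than are shown below. What is called first, only, known or untested is meant among the compounds shown, and "the series" means these compounds.

Measured compounds:
- compound 1, `Nc1ncnc2c1ncn2CC(O)C(=O)OCCO`; in a functional assay on HeLa cells (Homo sapiens) for cytotoxicity (a lower number here means that less compound is tolerated, a higher number that more compound is tolerated), compound 1 gives only a limit, > 400 ug/mL
- compound 2, `Nc1ncnc2c1ncn2CC(O)C(=O)OCc1ccco1`; in this assay compound 2 gives 40 ug/mL

Among the compounds with values here, compound 2 is therefore the single compound with an actual number in this assay; the other result is a limit of the assay the limit of > 400 ug/mL in this assay, at which 1 of the 2 values shown sits, and not a number. Within the data shown here, the one measured step runs to compound 2: an at least 10-fold lower number from compound 1 to compound 2 (1.00 log units; beyond the scatter). It touches the same place as the change now considered, the oxygen next to a carbonyl group.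

Compound 3, `CCC(C)OC(=O)C(O)Cn1cnc2c(N)ncnc21`, has not been measured. It differs from compound 2 as follows: sec-butyl in place of (furan-2-yl)methyl on an oxygen next to a carbonyl group.

Among the measured compounds shown here, only the step from compound 1 to compound 2 bears on this, and it is at least a modest one; it shows that the group on this oxygen can move the number beyond the scatter. Since the furan ring that accompanied the lower number now leaves, compound 3 is expected to move back toward a higher number, though short of the limit, and the expected step for compound 3 is estimated as a 2.5-fold higher number from compound 2 to compound 3 (0.40 log units; beyond the scatter). The estimate for compound 3 in this assay is 100 ug/mL, with a range from 30 ug/mL to 400 ug/mL.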

Compound 3, minimum cytotoxic concentration: > 400 ug/mL
Compound 3 gave a limit, no number; the forecaster's own chance of this, stated with the estimate: 25%; middle value at least 4.0-fold (0.60 log units) away from the limit.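

In this assay the change from (furan-2-yl)methyl to sec-butyl on the oxygen next to a carbonyl group gives an at least 10-fold higher number from compound 2 to compound 3 (1.00 log units; beyond the scatter) and so adds a second step at this place, starting this time from the compound with the lower number. Compound 1 alone, with its small 2-hydroxyethyl group, could not show whether any larger group on this oxygen would bring the lower number; compound 3 shows that sec-butyl, which has no ring, does not bring it. The step between compound 1 and compound 3 cannot be read, and two of the three compounds now rest at a limit of the assay rather than at a number: the limit of > 400 ug/mL in this assay, at which 2 of the 3 values shown sit.

As far as these compounds go, whether the lower number of compound 2 belongs to the furan ring in particular or to any ring on this oxygen stays open. A benzyl group or a thiophen-2-ylmethyl group at this place would separate those two readings, and a cyclohexyl group would show whether a ring without aromatic character behaves like sec-butyl or like (furan-2-yl)methyl.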